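A few compounds are considered here, and "the series" means these few. Any claim that something is new, unique, unknown or untested is made for them only; others in the source may bear on it.

Measured compounds:
compound 1, `Cc1noc(C)c1-c1ccc2c(c1)C(c1ccccc1)N(Cc1ncc(-c3ccccc3)o1)C(=O)N2C`, 50.6%
compound 2, `Cc1noc(C)c1-c1ccc2c(c1)C(c1ccccc1)N(Cc1nc(-c3ccccc3)cs1)C(=O)N2C`, 44.5%
compound 3, `Cc1noc(C)c1-c1ccc2c(c1)C(c1ccccc1)N(Cc1csc(-c3ccc(F)cc3)n1)C(=O)N2C`, 31.3%

In a functional assay on HepG2 cells (Homo sapiens) for inhibition, read by MTT assay, with a stated time of 48 h, tested at 2 uM (a higher number here means more inhibition at the concentration tested (going by the name of the read-out), a lower number less inhibition), compound 3 gives the lowest of the three numbers. Its nearest neighbour is compound 2, which stands a number 13.2 percentage points lower from compound 2 to compound 3 (beyond the scatter), and the furthest is compound 1, which stands a number 19.3 percentage points lower from compound 1 to compound 3 (beyond the scatter). Compound 4, `Cc1noc(C)c1-c1ccc2c(c1)C(c1ccccc1)N(Cc1nnc(-c3ccc(F)cc3)o1)C(=O)N2C`, has not yet been measured. It differs from compound 3 in one place: 5-(4-fluorophenyl)-1,3,4-oxadiazol-2-yl in place of 2-(4-fluorophenyl)-1,3-thiazol-4-yl on a saturated chain carbon bound to an amide-type nitrogen in a ring.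

Going by the values given here, no measured step swaps one five-membered ring for another while keeping the 4-fluorophenyl group, so no step answers this change directly. The two steps that come closest are the ring swap from compound 1 to compound 2, a number 6.1 percentage points lower from compound 1 to compound 2 (within the scatter), and the change from compound 2 to compound 3, a number 13.2 percentage points lower from compound 2 to compound 3 (beyond the scatter). The first shows that exchanging one small aromatic ring for another of the same kind moved the number little; the second shows that a change of both the ring and its attachment pattern gave a modest drop. Compound 4 returns to a ring carrying its aryl group in the manner of compound 1 and compound 2, so a small rise is expected, roughly a number 6.7 percentage points higher from compound 3 to compound 4 (within the scatter), though the scatter makes the direction uncertain. Compound 4 is therefore estimated at 38%, in a range from 22% to 54%.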

Compound 4, a percentage reported as inhibition, at one concentration (the size of the read-out at that concentration, not a potency): 52.8%
Compound 4: middle estimate off by 14.8 percentage points, on the low side; the range from low to high includes it.
By their numbers in this assay, from the lowest: compound 3; then compounds 2, 1 and 4 (each within the scatter of the next).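

In this assay the 4-fluorophenyl group stays the same and only the five-membered ring that carries it is exchanged, yet the number still shifts, with a number 21.5 percentage points higher from compound 3 to compound 4 (beyond the scatter) as the result. On this saturated chain carbon bound to an amide-type nitrogen in a ring, 5-(4-fluorophenyl)-1,3,4-oxadiazol-2-yl and 2-(4-fluorophenyl)-1,3-thiazol-4-yl are therefore not interchangeable, so the ring itself matters here even with the aryl group held constant. The earlier compounds shown here could not show this on their own. Each of their steps changed more than the ring. The other two steps, a number 8.3 percentage points higher from compound 2 to compound 4 (within the scatter) and a number 2.2 percentage points higher from compound 1 to compound 4 (within the scatter), show no separation of the new group from 4-phenyl-1,3-thiazol-2-yl or 5-phenyl-1,3-oxazol-2-yl, so the low number of compound 3 stands alone among the four.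

The compounds shown leave open how a plain 5-phenyl-1,3,4-oxadiazol-2-yl group would read, and how an amine or a carboxylic acid in place of the fluorine would read. No measurement of any property of these groups is at hand to account for the step.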